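Alkene for alkyne in a urotensin receptor agonist series

The source may report more compounds than this note shows. Statements on the series, on what has been measured and on what is new or still open speak of the compounds shown alone.

Compound 1 `Cc1ccc(C(CCN(C)C)NC(=O)C#Cc2ccccc2)cc1`: 3090 nM
Compound 2 `CN(C)CCC(NC(=O)C#Cc1ccccc1)c1ccc(Cl)cc1`: 398 nM

Of the compounds shown here, two have been measured in a functional assay on NIH3T3 cells for agonist activity at Urotensin-2 receptor (Homo sapiens), with a stated time of 5 days (on this read-out lower numbers stand for an effect already at smaller amounts and higher numbers for an effect only at larger amounts of compound), so far. Compound 1 gives 3090 nM in this assay, and compound 2 gives 398 nM. Among the compounds with values here, the one step between them, a 7.8-fold lower number from compound 1 to compound 2 (0.89 log units; beyond the scatter), concerns a chloro in place of methyl on an aromatic carbon, and it leaves compound 2 with the lowest of the two numbers.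

The next compound, compound 3 `CN(C)CCC(NC(=O)/C=C/c1ccccc1)c1ccc(Cl)cc1`, differs from compound 2 in a single place: 2-phenylethenyl in place of 2-phenylethynyl on a carbonyl carbon. Within the data shown here, no measured step touches this part of the molecule; the only step in hand, from compound 1 to compound 2, changes a ring substituent and says nothing about the linker to the carbonyl carbon. The expectation therefore rests on compound 2 alone, and the estimated step of a 1.5-fold higher number from compound 2 to compound 3 (0.18 log units; within the scatter) is kept small, with the change expected to fall within or only just beyond the scatter. For compound 3 the expected value in this assay is 600 nM, within a range from 150 nM to 2500 nM.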

Compound 3, half-maximal effective concentration: 427 nM
For compound 3 the middle estimate is 1.4-fold (0.15 log units) above the measured one; the measured number falls inside the stated range.
By their numbers in this assay, from the lowest: compounds 2 and 3 (each within the scatter of the next); then compound 1.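

In this assay, exchanging 2-phenylethynyl for 2-phenylethenyl on a carbonyl carbon gives a 1.1-fold higher number from compound 2 to compound 3 (0.03 log units; within the scatter) and so leaves compound 2 and compound 3 indistinguishable. Within the data shown here, this is the first reading at this position, and it shows that the triple bond outside the aromatic rings can give way to a double bond with no change that stands clear of the scatter, whereas the earlier step concerned only the ring substituent. Nothing at hand offers a reason why the two groups read alike.

Going by these compounds, whether a saturated 2-phenylethyl group on the carbonyl carbon, or a pyridyl ring in place of the phenyl ring of 2-phenylethenyl, would read alike remains open. Also open, on these data alone, is whether the same exchange would read alike with methyl in place of chloro, as in compound 1.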